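A few compounds are considered here, and "the series" means these few. Any claim that something is new, unique, unknown or untested is made for them only; others in the source may bear on it.

Of the compounds shown here, three from this series have been measured in a functional assay on HeLa cells (Homo sapiens) for inhibition, read by sulforhodamine B assay; a higher number here means a weaker inhibitor of growth, a lower number a stronger inhibitor of growth. Compound 1, with structure `CC1(C)CCC[C@]2(C)[C@@H](/C=C/C3=CC(=O)OC3)C(CO)=C(O)C(=O)[C@@H]12`, gives 79700 nM in this assay. Compound 2, with structure `C=C1CC[C@H]2C(C)(C)CCC[C@]2(C)[C@H]1C/C=C1/CC(O)OC1=O`, gives 47000 nM. Compound 3, with structure `C=C1CC[C@H]2C(C)(C)CCC[C@]2(C)[C@H]1CCC1=CC(O)OC1=O`, gives 36300 nM. All three numbers are high, so none of the compounds inhibits growth strongly. Compound 2 sits among the other two: its gap to compound 3 and its gap to compound 1 both lie within the usual scatter of repeated measurements, so the three cannot be told apart on these data.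

The step of interest runs from compound 2 to compound 4, whose structure is `C=C1CC[C@H]2C(C)(C)CCC[C@]2(C)[C@H]1C/C=C1/CC(OC)OC1=O`. The difference is methyl in place of hydrogen on an oxygen on a saturated carbon. Compound 4 keeps the whole core of compound 2 and changes only that hydroxy to methoxy. For the measured compounds named here, no comparable step between measured compounds exists in this set, so there is no direct precedent for what such a change does here.

Given that compound 2 gives 47000 nM, compound 4 is expected to behave much like it, with a step of a 1.1-fold lower number from compound 2 to compound 4 (0.05 log units; within the scatter) that is not expected to reach beyond the scatter in either direction. Compound 4 is therefore estimated at 42000 nM, within a range from 15000 nM to 120000 nM.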

Compound 4, concentration for 50% growth inhibition: > 100000 nM
Compound 4: no number, only a limit; the forecaster's own chance of this, stated with the estimate: 10%; middle value at least 2.3-fold (0.37 log units) from the limit.
By their numbers in this assay, from the lowest: compounds 3, 2 and 1 (each within the scatter of the next, the first and the last beyond it). At a limit, above all of these: compound 4.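

In this assay, for the compounds shown here, the change from hydroxy to methoxy gives an at least 2.1-fold higher number from compound 2 to compound 4 (0.32 log units; beyond the scatter), the first step that can be read at a single position, and it shows that this oxygen on a saturated carbon is not indifferent to what it carries: methyl in place of hydrogen here costs growth inhibition, by an amount beyond the scatter. Compound 4 stands at a limit of the assay, > 100000 nM, not at a number. The step is therefore only a lower bound on the loss, and its full size cannot be read from these data: the limit of > 100000 nM in this assay, at which 1 of the 4 values shown sits.

The compounds shown leave open whether the loss is specific to methyl or would also follow from a longer chain such as ethyl or from an acetyl group on this oxygen, and whether an amine in place of the hydroxy would keep the activity of compound 2. They also do not tell whether the same change would have the same effect on compound 3, which carries the same hydroxy on a different arrangement of the shared core.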